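The source may report more compounds than this note shows. Statements on the series, on what has been measured and on what is new or still open speak of the compounds shown alone.

Compound 3 `Cc1cncc(-c2cc(F)cc(-n3nnc(-c4ccccn4)n3)c2)c1` gives the highest number of the three measured compounds in a functional assay for antagonist activity at metabotropic glutamate receptor 5 (Rattus norvegicus) (a lower number here means a stronger inhibitor, a higher number a weaker inhibitor), at 499 nM. Compound 2 `Cc1cccnc1-c1cc(F)cc(-n2nnc(-c3ccccn3)n2)c1` gives 31 nM in this assay, and compound 1 `N#Cc1ccccc1-c1cc(F)cc(-n2nnc(-c3ccccn3)n2)c1` gives 6 nM. Compound 4 `Nc1cccnc1-c1cc(F)cc(-n2nnc(-c3ccccn3)n2)c1` has not yet been measured; it differs from compound 3 by 3-aminopyridin-2-yl in place of 5-methylpyridin-3-yl on an aromatic carbon. The measured step that bears most on this change is a 16-fold higher number from compound 2 to compound 3 (1.21 log units; beyond the scatter), since compound 2 carries the related 3-methylpyridin-2-yl group and that step ran in the direction opposite to the present change. The step of an 83-fold higher number from compound 1 to compound 3 (1.92 log units; beyond the scatter) points the same way. Among the compounds with values here, no measured pair shows amino in place of methyl, so that part of the change is untested. A large step back down is therefore expected, a 10-fold lower number from compound 3 to compound 4 (1.00 log units; beyond the scatter). Compound 4 is estimated at 50 nM, with a likely range from 10 nM to 300 nM.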

Compound 4, half-maximal inhibitory concentration: 19 nM
Compound 4: middle estimate off by 2.6-fold (0.42 log units), on the high side, and the stated range covers the measured number.
By their numbers in this assay, from the lowest: compound 1; then compounds 4 and 2 (each within the scatter of the next); then compound 3.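

The step of a 26-fold lower number from compound 3 to compound 4 (1.42 log units; beyond the scatter) in this assay shows that a pyridin-2-yl group at this position can carry amino instead of methyl, since the step of a 1.6-fold lower number from compound 2 to compound 4 (0.21 log units; within the scatter) leaves the two compounds within the scatter. The 2-cyanophenyl group still holds an edge, with a 3.2-fold higher number from compound 1 to compound 4 (0.50 log units; beyond the scatter) as the step to the amino compound. Nothing available explains these differences.

Still open, as far as these compounds go, is whether a hydroxyl or a methoxy group could replace the amino group, and whether a 3-cyanopyridin-2-yl group would match compound 1.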